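Taking one methyl off compound 2

The source may report more compounds than this note shows. Statements on the series, on what has been measured and on what is new or still open speak of the compounds shown alone.

In a functional assay on the whole organism with Mus musculus as the target (on this read-out higher numbers stand for an effect only at larger amounts of compound and lower numbers for an effect already at smaller amounts), compound 1 `CCn1c(-c2ccccc2)nn(C)c1=S` gives 0.58 mg/kg and compound 2 `Cc1ccc(-c2nn(C)c(=S)n2C)cc1` gives 1.74 mg/kg. Compound 2 thus holds the higher of the two numbers, with a gap beyond the usual scatter, so its effect needs the larger dose. Compound 3 `Cn1nc(-c2ccccc2)n(C)c1=S` has not been measured yet. Its structure differs from compound 2 by hydrogen in place of methyl on an aromatic carbon. Among the measured compounds shown here, no measured pair shows this change alone, so the size of the step is uncertain. Compound 1 also has hydrogen at that place and gives 0.58 mg/kg, which hints at a lower number, although it differs from compound 3 elsewhere. A modest drop in this assay is expected, perhaps none beyond the scatter. The estimate is a step of a 1.7-fold lower number from compound 2 to compound 3 (0.24 log units; within the scatter). For compound 3 the expected value is 1 mg/kg, with an estimated range of 0.4 mg/kg to 2.4 mg/kg.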

Compound 3, dose for half-maximal effect: 0.15 mg/kg
Beside the measured number, compound 3's estimate is 6.7-fold (0.82 log units) above it; the measured number lies below the stated range.
By their numbers in this assay, from the lowest: compound 3; then compound 1; then compound 2.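

In this assay, the methyl that leaves compound 2 turns out to matter a great deal: with hydrogen on that aromatic carbon, para to a group of 8 heavy atoms, the result is a 12-fold lower number from compound 2 to compound 3 (1.06 log units; beyond the scatter), a large step that the first two compounds could not reveal. A second single change, hydrogen in place of methyl on a saturated chain carbon bound to an aromatic nitrogen, gives a modest step, a 3.9-fold lower number from compound 1 to compound 3 (0.59 log units; beyond the scatter), so in both pairs the compound with the extra methyl needs the larger dose. Nothing measured here explains either step.

As far as these compounds go, whether a fluorine atom, a methoxy group or a longer chain on that aromatic carbon would also raise the number remains open. So does the effect of a propyl chain on the ring nitrogen.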